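Swapping the ether oxygen for sulfur in a diaminoquinoxaline series

A few compounds are considered here, and "the series" means these few. Any claim that something is new, unique, unknown or untested is made for them only; others in the source may bear on it.

Measured compounds:
- Compound 1, `Nc1cc(N)c2nc(-c3ccccc3)c(NCc3ccc(F)cc3)nc2c1`: 6920 nM
- Compound 2, `COc1ccc(Sc2nc3cc(N)cc(N)c3nc2-c2ccccc2)cc1`: < 100000 nM
- Compound 3, `Nc1cc(N)c2nc(-c3ccccc3)c(Oc3ccc(F)cc3)nc2c1`: 67600 nM

The three compounds share one core and differ only in the group attached to one aromatic carbon. In a functional assay on MDA-MB-435 cells (Homo sapiens) for inhibition, read by sulforhodamine B assay, with a stated time of 48 h (on this read-out higher numbers stand for lower toxicity in this test and lower numbers for higher toxicity in this test), compound 1 gives 6920 nM. Compound 3 gives 67600 nM in this assay, the highest of the two numbers shown. For compound 2 this assay reports only a limit, < 100000 nM, not a number.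

For the measured compounds named here, the one readable step is a 9.8-fold higher number from compound 1 to compound 3 (0.99 log units; beyond the scatter). The steps from compound 1 to compound 2 and from compound 2 to compound 3 cannot be sized, since compound 2 sits at the limit of < 100000 nM in this assay, at which 1 of the 3 values shown sits.

Compound 4, `Nc1cc(N)c2nc(-c3ccccc3)c(Sc3ccc(F)cc3)nc2c1`, has not been measured. Its difference from compound 3 is (4-fluorophenyl)sulfanyl in place of 4-fluorophenoxy on an aromatic carbon. Going by the values given here, no measured step changes oxygen for sulfur with the same ring in place, so there is no direct guide to the size of this step. Compound 2 carries a sulfur link and is reported only as a limit, which leaves its number open. The expectation for compound 4 is therefore a step of a 1.5-fold lower number from compound 3 to compound 4 (0.18 log units; within the scatter), within the scatter, and an estimated value of 45000 nM, between 12000 nM and 100000 nM.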

Compound 4, concentration lethal to 50% of the cells: 66100 nM
The estimate for compound 4 lay 1.5-fold (0.17 log units) below the measured number; the range from low to high includes it.
By their numbers in this assay, from the lowest: compound 1; then compounds 4 and 3 (each within the scatter of the next).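

In this assay, the oxygen link gives way to a sulfur link with the same 4-fluorophenyl ring in place, the one direct test of this exchange, and the result is a 1.0-fold lower number from compound 3 to compound 4 (0.01 log units; within the scatter); on this aromatic carbon next to the ring nitrogen, the two links cannot be told apart in this test. Compound 4 also shows that the separation of compound 1 from the oxygen-linked compound 3 recurs with a sulfur link, as (4-fluorophenyl)sulfanyl in place of (4-fluorobenzyl)amino gives a 9.6-fold higher number from compound 1 to compound 4 (0.98 log units; beyond the scatter). The step between compound 2 and compound 4, which would show what fluoro in place of methoxy does on the sulfur-linked ring, cannot be read, because compound 2 is reported only as a limit: the limit of < 100000 nM in this assay, at which 1 of the 4 values shown sits.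

The compounds shown leave open which part of the (4-fluorobenzyl)amino group goes with the lower number of compound 1: its amino nitrogen or the extra carbon that joins that nitrogen to the ring. A 4-fluoroanilino group, with the nitrogen bonded directly to the ring, or a 4-fluorobenzyloxy group, which keeps the extra carbon but has oxygen in place of the nitrogen, would help separate the two.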